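The source may hold more compounds than are shown below. What is called first, only, known or untested is meant among the compounds shown, and "the series" means these compounds.

Compound 1, `CC(C)[C@@H](NC(=O)c1nc2ccccc2s1)C(=O)N1CCC(c2ccc(Cl)cc2)CC1`, is measured in an assay on THP-1 cells for displacement of a labelled ligand from C-C chemokine receptor type 1 (Homo sapiens) (a higher number here means a weaker inhibitor, a lower number a stronger inhibitor), and gives 18 nM. Within the data shown here, this is the lowest of the two numbers known so far. Compound 2, `CC(C)C(NC(=O)c1ccc2ccccc2c1)C(=O)N1CCC(c2ccc(Cl)cc2)CC1`, gives 80 nM in this assay, a higher number, and the gap from compound 1 lies beyond the usual scatter. Compound 3, `Cc1ccccc1CCC(=O)N[C@@H](C(=O)N1CCC(c2ccc(Cl)cc2)CC1)C(C)C`, has not yet been measured. It differs from compound 1 in one place: 2-(2-methylphenyl)ethyl in place of 1,3-benzothiazol-2-yl on a carbonyl carbon. Among the measured compounds shown here, no comparable step has been measured. A modest loss of binding is expected, which means an expected step of an 8.3-fold higher number from compound 1 to compound 3 (0.92 log units; beyond the scatter). Compound 3 is expected to give about 150 nM, likely between 40 nM and 600 nM.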

Compound 3, half-maximal inhibitory concentration: 19 nM
Estimate against measurement, compound 3: 7.9-fold (0.90 log units) above; measured number outside the range, below it.
By their numbers in this assay, from the lowest: compounds 1 and 3 (each within the scatter of the next); then compound 2.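

In this assay, putting 2-(2-methylphenyl)ethyl in place of 1,3-benzothiazol-2-yl on a carbonyl carbon gives a 1.1-fold higher number from compound 1 to compound 3 (0.02 log units; within the scatter), so this position accepts two quite different groups with no measurable difference. The entering group is all carbon, so in this pair the two hydrogen-bond acceptors of the leaving group are not needed for this binding number. Nothing shown explains why the two groups match. Going by these compounds, whether this position would also accept an amine or a carboxylic acid remains open. So does the outcome for a longer chain, or for a plain phenyl without the methyl.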